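The source may hold more compounds than are shown below. What is called first, only, known or untested is meant among the compounds shown, and "the series" means these compounds.

Measured so far in an ADME assay on Li23 cells (Homo sapiens) for cytotoxicity, read by WST assay; on this read-out higher numbers stand for lower toxicity in this test and lower numbers for higher toxicity in this test:
compound 1, `CN(C(=O)c1ccccc1)c1ccc(C(OCCO)(C(F)(F)F)C(F)(F)F)cc1`: > 20000 nM, a limit of the assay rather than a number.
compound 2, `CN(c1ccc(C(O)(C(F)(F)F)C(F)(F)F)cc1)S(=O)(=O)c1ccccc1Cl`: 15000 nM.
compound 3, `CN(c1ccc(C(O)(C(F)(F)F)C(F)(F)F)cc1)S(=O)(=O)c1ccccc1Br`: 9100 nM.

Compound 3 sits lowest of the two numbers given in this assay; its nearest neighbour is compound 2, and the step of a 1.6-fold lower number from compound 2 to compound 3 (0.22 log units; within the scatter) is within the scatter. For compound 1 only a limit is known, (the limit of > 20000 nM in this assay, at which 1 of the 3 values shown sits).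

The next compound, compound 4 `Cc1ccccc1S(=O)(=O)N(C)c1ccc(C(O)(C(F)(F)F)C(F)(F)F)cc1`, differs from compound 3 in one place: methyl in place of bromo on an aromatic carbon.

Within the data shown here, only one measured step bears on this change, the exchange of one halogen for another on an aromatic carbon, a 1.6-fold lower number from compound 2 to compound 3 (0.22 log units; within the scatter), which stayed within the scatter. A methyl entering in place of bromo has no measured counterpart among these compounds; the single step on that carbon gives no ground to expect a move beyond the scatter in this assay. Compound 4 is therefore expected close to compound 3, with the step of a 1.1-fold higher number from compound 3 to compound 4 (0.04 log units; within the scatter) estimated as within the scatter. The estimate for compound 4 is 10000 nM, with a range from 4000 nM to 25000 nM.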

Compound 4, half-maximal cytotoxic concentration: 12000 nM
Estimate against measurement, compound 4: 1.2-fold (0.08 log units) below; the range from low to high includes it.
By their numbers in this assay, from the lowest: compounds 3, 4 and 2 (each within the scatter of the next). At a limit, above all of these: compound 1.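

In this assay, this place, ortho to a large group, now has a carbon group as well as halogens: methyl in place of bromo gives a 1.3-fold higher number from compound 3 to compound 4 (0.12 log units; within the scatter), and methyl in place of chloro gives a 1.3-fold lower number from compound 2 to compound 4 (0.10 log units; within the scatter). Both steps lie within the scatter, so compound 2, compound 3 and compound 4 cannot be ordered in this assay, and the change from halogen to methyl leaves no readable trace here. Nothing shown accounts for how small these steps are.

From the compounds shown here alone, it remains open whether any group at this place moves the number beyond the scatter, for example an amine, a carboxylic acid or a longer chain such as propyl. Also open, going by these compounds, is what the plain phenyl, with hydrogen at this place, would give.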